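The source may report more compounds than this note shows. Statements on the series, on what has been measured and on what is new or still open speak of the compounds shown alone.

Compound 1 `CCc1nn(CC)c(C2CCN(C(=O)CN3CN(c4ccccc4)C4(CCN(C(=O)c5ccc(C6CCCCC6)cc5)CC4)C3=O)CC2)c1C` — in an assay on HEK293 cells for displacement of a labelled ligand from NPC1-like intracellular cholesterol transporter 1 (Homo sapiens) (a lower number here means a stronger inhibitor, a higher number a weaker inhibitor), compound 1 gives "not determined" (no result reported), so no number was reported for it.
Compound 2 `CC(C)(C)c1ccc(C(=O)N2CCC3(CC2)C(=O)N(CC(=O)NCCCN)CN3c2ccccc2)cc1` — in this assay compound 2 gives 4200 nM.
Compound 3 `CC(C)(C)OC(=O)NCC1CCCN(C(=O)CN2CN(c3ccccc3)C3(CCN(C(=O)c4ccc(C(C)(C)C)cc4)CC3)C2=O)C1` — in this assay compound 3 gives 9500 nM.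

Going by the values given here, only two numbers are known, and compound 2 holds the lower of them; the number for compound 3 is higher, and the gap between the two lies beyond the usual scatter of repeated measurements. Compound 1 adds nothing here, since no result was reported for it.

Compound 4 `CC(C)(C)c1ccc(C(=O)N2CCC3(CC2)C(=O)N(CC(=O)NCCCCO)CN3c2ccccc2)cc1` shares the core of compound 2 and differs from it in one place: hydroxymethyl in place of amino on a saturated chain carbon, three bonds along the chain from an amide-type nitrogen. Hydroxymethyl replaces amino on a saturated chain carbon, three bonds along the chain from an amide-type nitrogen.

Among the compounds with values here, no pair of measured compounds shows this particular change, so nothing in the data gives the direction or size of its effect on this assay. With a hydrogen-bond donor and acceptor leaving and a hydrogen-bond donor and acceptor entering, the expected step from compound 2 to compound 4 is small, perhaps none beyond the scatter, and the expected step is a 1.2-fold higher number from compound 2 to compound 4 (0.08 log units; within the scatter). Compound 4 is estimated at 5000 nM, within a range of 1500 nM to 16000 nM.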

Compound 4, half-maximal inhibitory concentration: 19200 nM
The estimate for compound 4 lay 3.8-fold (0.58 log units) below the measured number; the whole stated range lies below it.
By their numbers in this assay, from the lowest: compound 2; then compound 3; then compound 4.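

Replacing amino with hydroxymethyl on a saturated chain carbon, three bonds along the chain from an amide-type nitrogen, gives a 4.6-fold higher number from compound 2 to compound 4 (0.66 log units; beyond the scatter) in this assay. This position therefore responds to the identity of the group placed there, even though the groups that leave and enter each count one hydrogen-bond donor, one hydrogen-bond acceptor and no net charge. No measurement here bears on why the number rises.

The change swaps nitrogen for oxygen and also adds a carbon, so these compounds cannot show which of the two matters; a 3-hydroxypropyl group in place of the 3-aminopropyl group would separate them. As far as these compounds go, how a carboxylic acid or a dimethylamino group would behave in place of the amino group also remains open.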